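The source may report more compounds than this note shows. Statements on the series, on what has been measured and on what is new or still open speak of the compounds shown alone.

For the measured compounds named here, compound 2 `COc1ccc(Nc2nc(Nc3cc(C)[nH]n3)cc(N3CCN(C)CC3)n2)cc1OC` is one of two compounds measured in a functional assay on A-431 cells (Homo sapiens) for antiproliferative activity, read by CCK-8 assay, with a stated time of 48 h (on this read-out lower numbers stand for stronger inhibition and higher numbers for weaker inhibition), where compound 2 gives 778 nM. Going by the values given here, its only neighbour is compound 1 `Cc1cc(Nc2cc(N3CCN(C)CC3)nc(Nc3ccc(F)cc3)n2)n[nH]1`, which in this assay gives 340 nM; compound 2 thus stands as the higher of the two numbers, and the one step between them, a 2.3-fold higher number from compound 1 to compound 2 (0.36 log units; beyond the scatter), came with the 3,4-dimethoxyphenyl entering in place of 4-fluorophenyl. Compound 3 `Cc1cc(Nc2cc(N3CCN(C)CC3)nc(Nc3ccc(Cl)c(F)c3)n2)n[nH]1` differs from compound 2 in the same place: 4-chloro-3-fluorophenyl in place of 3,4-dimethoxyphenyl on a nitrogen on an aromatic ring. Among the compounds with values here, no measured step covers this exact exchange, but the step from compound 1 to compound 2 shows what the 3,4-dimethoxyphenyl cost, and compound 3 returns to a halogenated phenyl like that of compound 1. A modest fall in the number is therefore expected, of the order of a 2.6-fold lower number from compound 2 to compound 3 (0.41 log units; beyond the scatter), so that compound 3 is estimated to give 300 nM in this assay, with a range of 120 nM to 800 nM.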

Compound 3, half-maximal inhibitory concentration: 136 nM
Estimate against measurement, compound 3: 2.2-fold (0.34 log units) above; measured number inside the range.
By their numbers in this assay, from the lowest: compound 3; then compound 1; then compound 2.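

At this position, on a nitrogen on an aromatic ring, the choice of phenyl group moves the number in this assay further than the first pair showed: the change to 4-chloro-3-fluorophenyl gives a 5.7-fold lower number from compound 2 to compound 3 (0.76 log units; beyond the scatter). A halogenated phenyl is also not a single level of activity here, since the same group gives a 2.5-fold lower number from compound 1 to compound 3 (0.40 log units; beyond the scatter), which makes compound 3 the most potent of the three, and the order now runs beyond the scatter among all three compounds. Nothing available explains why the 4-chloro-3-fluorophenyl group gives the lowest number.

The compounds shown cannot separate the share of the chlorine from that of the added fluorine, as a 4-chlorophenyl group does not appear among them. Going by these compounds, how a plain phenyl, or a phenyl carrying an amine or a carboxylic acid, would read at this position also remains open.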